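A few compounds are considered here, and "the series" means these few. Any claim that something is new, unique, unknown or untested is made for them only; others in the source may bear on it.

Compounds measured in this assay so far:
compound 1 `CC(C)(C)CC#Cc1cc2ncnc(Nc3ccc(OCc4cccc(F)c4)c(Cl)c3)c2s1`, > 50 uM
compound 2 `CCCN(CC#Cc1cc2ncnc(Nc3ccc(OCc4cccc(F)c4)c(Cl)c3)c2s1)CCC`, > 50 uM
compound 3 `CC(C)(C)CC#Cc1cc2c(Nc3ccc(OCc4cccc(F)c4)c(Cl)c3)ncnc2s1`, > 50 uM

In an ADME assay on NIH3T3 cells (Mus musculus) for cytotoxicity (a lower number here means that less compound is tolerated, a higher number that more compound is tolerated), compound 1 reaches only a limit of the assay, > 50 uM. Compound 2 likewise stops at a limit, > 50 uM. Compound 3 also gives a limit, > 50 uM. Compound 1 and compound 2 differ in one place, (dipropylamino in place of tert-butyl on a saturated chain carbon bound to a triple-bonded carbon), and the step that change made in this assay is a step that the two limits leave unreadable from compound 1 to compound 2. All three values share one point: the limit of > 50 uM in this assay, at which 3 of the 3 values shown sit. Compound 3 holds the same atoms as compound 1, joined differently; the difference between the two cores is not broken down here.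

Compound 4 `CCCN(CC#Cc1cc2c(Nc3ccc(OCc4cccc(F)c4)c(Cl)c3)ncnc2s1)CCC` is not yet measured. It differs from compound 3 by the same change, (dipropylamino in place of tert-butyl on a saturated chain carbon bound to a triple-bonded carbon). Its step from compound 3 in this assay is expected to be a step that the limit leaves unreadable from compound 3 to compound 4, resting on the unreadable step seen at the limit in a step that the two limits leave unreadable from compound 1 to compound 2. For compound 4 the estimate in this assay is 60 uM.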

Compound 4, half-maximal toxic concentration: 2.2 uM
For compound 4 the middle estimate is 27-fold (1.44 log units) above the measured one; the measured number lies below the stated range.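

In this assay, dipropylamino in place of tert-butyl on a saturated chain carbon bound to a triple-bonded carbon gives an at least 22-fold lower number from compound 3 to compound 4 (1.35 log units; beyond the scatter), so on the core of compound 3 the change has a large effect. On the core of compound 1 the same change gives a step that cannot be read, so the compounds show neither that the effect carries over from one core to the other nor that it is confined to one core. The comparison stops at a single limit: the limit of > 50 uM in this assay, at which 3 of the 4 values shown sit.

On these data alone, it remains open whether the large step follows from the dipropylamino group as a whole or from any amine in that place. Dimethylamino, morpholine or a hydroxyl group on the same saturated chain carbon would bear on this question.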